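The source may hold more compounds than are shown below. What is called first, only, known or untested is meant among the compounds shown, and "the series" means these compounds.

Measured compounds in a functional assay on HeLa cells (Homo sapiens) for cytotoxicity, read by neutral red uptake, with a stated time of 3 days; a lower number here means a stronger inhibitor, a higher number a weaker inhibitor:
compound 1, `Cc1c(F)c(N)c2c(=O)cc(-c3ccc(N)c(F)c3)oc2c1F`; compound 1 gives > 100000 nM, which is a limit of the assay.
compound 2, `CCCCc1c(F)c(N)c2c(=O)cc(-c3ccc(N)c(F)c3)oc2c1F`; compound 2 gives > 100000 nM, which is a limit of the assay.
compound 3, `CN(C)c1c(F)c(N)c2c(=O)cc(-c3ccc(N)c(F)c3)oc2c1F`; compound 3 gives > 100000 nM, which is a limit of the assay.

Compound 1 stands on no number in this assay, only on a limit, and the two other values shown are limits as well, so compound 1 cannot be placed above or below either of them.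

Compound 4, `CCOC(=O)c1c(F)c(N)c2c(=O)cc(-c3ccc(N)c(F)c3)oc2c1F`, differs from compound 1 in one place: ethoxycarbonyl in place of methyl on an aromatic carbon.

The measured steps that touch this position are a step that the two limits leave unreadable from compound 1 to compound 2, a step that the two limits leave unreadable from compound 1 to compound 3 and a step that the two limits leave unreadable from compound 2 to compound 3. None of them has a readable size, because all three values sit at the limit of > 100000 nM in this assay, at which 3 of the 3 values shown sit. Within these three compounds the group on this aromatic carbon has not moved the read-out off the limit, whether methyl, butyl or dimethylamino stands there.

For compound 4 no step beyond the scatter is therefore expected in this assay; the expected outcome is again a value at the limit or close to it. The expected step is a number no higher from compound 1 to compound 4 (the limit leaves the size open). Compound 4 is estimated at 100000 nM, with a range from 30000 nM to 300000 nM.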

Compound 4, half-maximal inhibitory concentration: > 100000 nM
Compound 4: only a limit was reported; the forecaster's own chance of this, stated with the estimate: 80%; the middle value lies on the limit itself.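

In this assay compound 4 gives > 100000 nM, which is a limit of the assay. No new step can be read between compound 4 and compound 1, compound 2 or compound 3, because all four values sit at the same limit: the limit of > 100000 nM in this assay, at which 4 of the 4 values shown sit.

The compounds shown leave open whether any group on this aromatic carbon can move the read-out off the limit.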